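The compounds below may be only part of what the source reports. "The series", "measured", "known", "first", "only" and "open" are said of these compounds alone.

Measured so far:
compound 1, `CNc1nc(NC2(C#N)CCCCC2)nc(-n2cnc(C)n2)n1` — > 276 mL/min/kg
compound 2, `CCC(C)(C#N)Nc1nc(NC)nc(-n2cncn2)n1` — 32 mL/min/kg
compound 3, `CNc1nc(NC(C#N)(C2CC2)C2CC2)nc(-n2cncn2)n1` — 3.7 mL/min/kg

In an ADME assay on microsomes from liver (Rattus norvegicus) for metabolic stability (a lower number here means slower removal, a higher number faster removal of the compound), compound 1 gives only a limit, > 276 mL/min/kg, not a number. Compound 1 therefore stands at the limit of > 276 mL/min/kg in this assay, at which 1 of the 3 values shown sits, the top of what the series has shown. In this assay, within the data shown here, compound 2 gives 32 mL/min/kg and compound 3 gives 3.7 mL/min/kg, both as numbers; no single-change pairs connect these three, so their values are noted without ranking.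

Compound 4, `CNc1nc(NC2(C#N)CCCCC2)nc(SC)n1`, is not yet measured in this assay. Against compound 1 the change is methylsulfanyl in place of 3-methyl-1H-1,2,4-triazol-1-yl on an aromatic carbon. Among the measured compounds shown here, no measured step covers this change, so its direction is not known from the data. A downward step of moderate size is expected, to be visible only if it goes beyond the scatter. For compound 4 the estimate in this assay is 150 mL/min/kg, with a range from 40 mL/min/kg to 300 mL/min/kg. The step this estimate means, an at least 1.8-fold lower number from compound 1 to compound 4 (0.26 log units; that floor lies within the scatter), is expected to be downward and larger than the scatter.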

Compound 4, clearance: 579 mL/min/kg
Compound 4: the middle estimate sits 3.9-fold (0.59 log units) below what was measured; measured number above the stated range.
By their numbers in this assay, from the lowest: compound 3; then compound 2; then compound 4.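

The step from compound 1 to compound 4 cannot be read in this assay, because compound 1 gives a limit and not a number: the limit of > 276 mL/min/kg in this assay, at which 1 of the 4 values shown sits.

The compounds shown leave open the direction and size of the change in clearance when methylsulfanyl takes the place of 3-methyl-1H-1,2,4-triazol-1-yl.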